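Oxocyclohexyl to Morpholinylmethyl: Expectation for Compound 3

This account rests on a few compounds, and the source may have more. Where it says the series, first, only, none or still open, it means among the compounds named here.

compound 1 `Cc1n[nH]c2nc(-c3ccc(NS(=O)(=O)c4cc(Cl)ccc4F)cc3)nc(OCC3(CN)COC3)c12` — 1 nM
compound 2 `Cc1n[nH]c2nc(-c3ccc(NS(=O)(=O)c4cc(Cl)ccc4F)cc3)nc(OC3CCC(=O)CC3)c12` — 5 nM

In an assay for inhibition of serine/threonine-protein kinase Sgk1 (Homo sapiens), with stated times of 30 min and 60 min, in the presence of a further agent that is not named here (a higher number here means a weaker inhibitor, a lower number a stronger inhibitor), compound 1 gives 1 nM, and compound 2 gives 5 nM. For the measured compounds named here, compound 2 therefore stands at the higher of the two numbers, the only neighbour being compound 1, reached by a 5.0-fold higher number from compound 1 to compound 2 (0.70 log units; beyond the scatter).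

Compound 3 `Cc1n[nH]c2nc(-c3ccc(NS(=O)(=O)c4cc(Cl)ccc4F)cc3)nc(OCC3CNCCO3)c12` differs from compound 2 in one place: (morpholin-2-yl)methyl in place of 4-oxocyclohexyl on an oxygen on an aromatic ring. Going by the values given here, the single measured step that bears on this is the one from compound 1 to compound 2, in which a side chain carrying a nitrogen was replaced by one without, and the number rose by a 5.0-fold higher number from compound 1 to compound 2 (0.70 log units; beyond the scatter). Compound 3 again carries a nitrogen in its side chain, as compound 1 does, so the change is expected to run the other way, with a step of about a 2.5-fold lower number from compound 2 to compound 3 (0.40 log units; beyond the scatter). Compound 3 is thus estimated at 2 nM, within a range of 0.7 nM to 6 nM.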

Compound 3, half-maximal inhibitory concentration: 2 nM
Compound 3: the middle estimate sits on the measured number at the digits printed; low and high end bracket the measured number.
By their numbers in this assay, from the lowest: compounds 1 and 3 (each within the scatter of the next); then compound 2.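

In this assay, replacing 4-oxocyclohexyl with (morpholin-2-yl)methyl gives a 2.5-fold lower number from compound 2 to compound 3 (0.40 log units; beyond the scatter), so a second nitrogen-bearing side chain on this oxygen now has a lower number than the nitrogen-free compound 2. Two differently built rings carrying a nitrogen also cannot be told apart here: the change to morpholin-2-yl from 3-(aminomethyl)oxetan-3-yl gives a 2.0-fold higher number from compound 1 to compound 3 (0.30 log units; within the scatter). Among these three compounds, the two with a side-chain nitrogen both have lower numbers than compound 2, which has none, and no compound goes against this.

On these data alone, still, compound 2 differs from compound 3 in more than the nitrogen, so that atom's own contribution remains open. A (tetrahydropyran-2-yl)methyl group, with a ring carbon in place of the morpholine nitrogen, would separate the nitrogen from the ring and its chain. No supporting evidence is available to explain these differences.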